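Hydroxy Replaces Methyl on the Chain of Compound 3

The source may report more compounds than this note shows. Statements on the series, on what has been measured and on what is new or still open speak of the compounds shown alone.

Of the compounds shown here, three have been measured in an assay on isolated protein for inhibition of Flap endonuclease 1 (Homo sapiens); a higher number here means a weaker inhibitor, a lower number a stronger inhibitor. Compound 1 `CC(=O)Nc1ccc2[nH]c(=O)n(O)c(=O)c2c1` gives 2000 nM. Compound 2 `CNC(=O)c1nc(-c2cccs2)[nH]c(=O)c1O` gives 12000 nM, and compound 3 `CCCNC(=O)c1nc(-c2cccs2)[nH]c(=O)c1O` gives 4200 nM. Compound 3 therefore stands second highest of the three, with compound 1 nearest and compound 2 furthest. The one step among these compounds that differs in a single place is a 2.9-fold lower number from compound 2 to compound 3 (0.46 log units; beyond the scatter), an ethyl in place of hydrogen on the saturated chain carbon bound to the amide-type nitrogen.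

Compound 4 `O=C(NCCO)c1nc(-c2cccs2)[nH]c(=O)c1O` is to be measured next. It differs from compound 3 by hydroxy in place of methyl on a saturated chain carbon, two bonds along the chain from an amide-type nitrogen, so that the propyl becomes a 2-hydroxyethyl. For the measured compounds named here, only the step from compound 2 to compound 3 bears on this part of the structure, and it was modest; nothing measured here covers a hydroxy on this chain. With the chain cut back toward what compound 2 carries, part of the gain seen in that step may be given back. For compound 4 a modest upward step in this assay is expected, a 1.4-fold higher number from compound 3 to compound 4 (0.15 log units; within the scatter). Compound 4 is estimated at 6000 nM, within 2500 nM to 15000 nM.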

Compound 4, half-maximal inhibitory concentration: 4000 nM
Compound 4: middle estimate off by 1.5-fold (0.18 log units), on the high side, and the stated range covers the measured number.
By their numbers in this assay, from the lowest: compounds 1, 4 and 3 (each within the scatter of the next, the first and the last beyond it); then compound 2.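

In this assay, hydroxy in place of methyl on this chain carbon, two bonds along the chain from an amide-type nitrogen, gives a 1.1-fold lower number from compound 3 to compound 4 (0.02 log units; within the scatter), so the 2-hydroxyethyl and the propyl cannot be told apart here. The 2-hydroxyethyl also stands clear of the shorter chain of compound 2, with a 3.0-fold lower number from compound 2 to compound 4 (0.48 log units; beyond the scatter), much as the propyl does with a 2.9-fold lower number from compound 2 to compound 3 (0.46 log units; beyond the scatter); the gain over compound 2 therefore does not need the terminal methyl of the propyl. Nothing at hand explains why the exchange leaves the number in place.

On these data alone, whether an amine or a carboxylic acid in place of the hydroxy would hold the number of compound 4 remains open. So does whether a methoxy there, or a longer chain, would do the same.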